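The compounds below may be only part of what the source reports. "The series", "measured", "known", "first", "only" and "open" are said of these compounds alone.

Compound 1 `Nc1nc(N)c(C(=O)Nc2ccccn2)nc1Cl`: 3800 nM
Compound 2 `Nc1ncc(Cl)nc1C(=O)Nc1ccccn1`: 11 nM
Compound 3 `Cc1cccc(NC(=O)c2cccc(C)n2)n1`: 32 nM

These numbers come from an assay on Ltk cells for inhibition of metabotropic glutamate receptor 5 (Homo sapiens), read by fluorescence; on this read-out lower numbers stand for stronger inhibition and higher numbers for weaker inhibition. Compound 4 `Cc1cccc(NC(=O)c2nc(C)ccc2N)n1` awaits measurement in this assay. The difference between the core of compound 3 and the core of compound 2 is not broken down here. From compound 3 to compound 4 the change is amino in place of hydrogen on an aromatic carbon; from compound 2 to compound 1 it is amino in place of hydrogen on an aromatic carbon. The surroundings differ: in compound 1 the site lies on a ring with 2 nitrogen, next to the ring nitrogen, ortho to a chloro group, meta to an amino group and para to a group of 9 heavy atoms, whereas in compound 4 it lies on a ring with 1 nitrogen, ortho to a large group and para to a methyl group. It is the same kind of change, not the same. The measured step was a 350-fold higher number from compound 2 to compound 1 (2.54 log units; beyond the scatter). For compound 4 a clear rise is expected, a 19-fold higher number from compound 3 to compound 4 (1.27 log units; beyond the scatter), resting on compound 3 at 32 nM and on the large step of a 350-fold higher number from compound 2 to compound 1 (2.54 log units; beyond the scatter), tempered by the different surroundings. Compound 4 is estimated at 600 nM, between 100 nM and 4000 nM.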

Compound 4, half-maximal inhibitory concentration: 22 nM
Estimate against measurement, compound 4: 27-fold (1.44 log units) above; the measured number lies below the stated range.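

In this assay, amino in place of hydrogen on an aromatic carbon gives a 1.5-fold lower number from compound 3 to compound 4 (0.16 log units; within the scatter), so on this core the change has no readable effect on the number. The result does not carry over between the two cores: the same change on two cores in this assay, a 350-fold higher number (2.54 log units; beyond the scatter) from compound 2 to compound 1 and a 1.5-fold lower number (0.16 log units; within the scatter) from compound 3 to compound 4, 500-fold (2.70 log units) apart, beyond the scatter of two such steps. The two pairs show that this change cannot be transferred from one core to the other in this series, but they do not separate the role of the core from that of the site on the ring, and they do not predict a third core.

Still open, as far as these compounds go, is whether a hydroxyl, methylamino or dimethylamino group at the same place on the core of compound 3 would also leave the number within the scatter.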